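A few compounds are considered here, and "the series" means these few. Any claim that something is new, unique, unknown or untested is made for them only; others in the source may bear on it.

Of the compounds shown here, three have been measured in a functional assay on A2780 cells (Homo sapiens) for inhibition, read by MTT assay, with a stated time of 72 h; a higher number here means a weaker inhibitor of growth, a lower number a stronger inhibitor of growth. Compound 1, `COc1ccc(CNC(=O)/C(C#N)=C/c2ccco2)cc1`, gives 24000 nM in this assay. Compound 2, `COc1ccc(CNC(=O)/C(C#N)=C/c2ccc(Cl)o2)cc1`, gives 9000 nM. The change between them, (chloro in place of hydrogen on an aromatic carbon), produced a 2.7-fold lower number from compound 1 to compound 2 (0.43 log units; beyond the scatter). Compound 3, `N#C/C(=C\c1ccccc1)C(=O)NCc1ccc(Cl)c(Cl)c1`, gives 49000 nM, the highest of the three numbers; the difference between the core of compound 3 and the core of compound 1 is not broken down here.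

Compound 4, `N#C/C(=C\c1ccc(Cl)cc1)C(=O)NCc1ccc(Cl)c(Cl)c1`, has not yet been measured. It differs from compound 3 by chloro in place of hydrogen on an aromatic carbon. This is the same kind of change as the one from compound 1 to compound 2, and among the compounds shown it occurs two times in all, but it is not the same change: in compound 2 the chloro sits on a five-membered aromatic ring with one oxygen, next to the ring oxygen and two ring bonds from the ring atom that bears a large group, whereas in compound 4 it sits on a six-membered aromatic ring of carbon only, para to a large group.

Among the measured compounds shown here, because the only measured instance of this kind of change is a 2.7-fold lower number from compound 1 to compound 2 (0.43 log units; beyond the scatter), the step from compound 3 to compound 4 in this assay is expected to be of similar size and direction, about a 2.5-fold lower number from compound 3 to compound 4 (0.39 log units; beyond the scatter), with the caveat that it rests on a single pair and a different ring. Compound 4 is therefore estimated at 20000 nM, expected to fall between 8000 nM and 50000 nM.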

Compound 4, concentration for 50% growth inhibition: 32000 nM
Estimate against measurement, compound 4: 1.6-fold (0.20 log units) below; the range from low to high includes it.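

In this assay, chloro in place of hydrogen on an aromatic carbon gives a 1.5-fold lower number from compound 3 to compound 4 (0.19 log units; within the scatter), so on the core of compound 3 the change alone does not stand clear of the usual scatter. Set beside the earlier step on the core of compound 1, the new step cannot be told apart from it, and the two pairs are consistent with a change that carries across these two cores with the same direction and a similar, small size: the same change on two cores in this assay, a 2.7-fold lower number (0.43 log units; beyond the scatter) from compound 1 to compound 2 and a 1.5-fold lower number (0.19 log units; within the scatter) from compound 3 to compound 4, 1.7-fold (0.24 log units) apart, within the scatter of two such steps. Among the compounds shown here, this does not show that the change has a fixed size, or that it lowers the number on every core, since it rests on only two pairs, one of which lies within the scatter, and these two pairs cannot say whether the ring that bears the chloro matters.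

The compounds shown leave open whether a group other than chloro at these places, such as fluoro, methoxy or an amine, would give a step of like size. They also leave open how the same change would read if the nitrile of the shared core gave way to another group, such as a carboxylic acid.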